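This account rests on a few compounds, and the source may have more. Where it says the series, first, only, none or still open, it means among the compounds named here.

The compounds here share one core and were tested in a functional assay on FaDu cells (Homo sapiens) for cytotoxicity, read by MTT assay, with a stated time of 72 h; on this read-out higher numbers stand for lower toxicity in this test and lower numbers for higher toxicity in this test. Compound 1 `CC(C)n1cc(C(=O)C(=O)Nc2ccc(C(F)(F)F)nc2)c2ccccc21` carries a trifluoromethyl group; in this assay compound 1 gives only a limit of the assay, > 10000 nM. Compound 2 `COc1ccc(NC(=O)C(=O)c2cn(C(C)C)c3c(Cl)cccc23)cn1` carries a methoxy group and a chloro as well; in this assay compound 2 gives 10200 nM. Compound 3 `COc1ccc(NC(=O)C(=O)c2cn(C(C)C)c3ccccc23)cn1` keeps the methoxy and has hydrogen in place of the chloro; in this assay compound 3 gives 85 nM.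

Compound 3 stands lowest of the two numbers shown, so it is the most toxic compound measured here. The nearest number belongs to compound 2, and the step is a 120-fold lower number from compound 2 to compound 3 (2.08 log units; beyond the scatter). The other step, an at least 110-fold lower number from compound 1 to compound 3 (2.07 log units; beyond the scatter), starts from a limit of > 10000 nM in this assay, at which 1 of the 3 values shown sits, rather than from a number.

Compound 4 `COC(=O)CCn1cc(C(=O)C(=O)Nc2ccc(OC)nc2)c2ccccc21` has not yet been measured in this assay. It differs from compound 3 in one place: 2-(methoxycarbonyl)ethyl in place of isopropyl on an aromatic nitrogen. Neither measured step touches this place: both changed a group on an aromatic carbon, while this change sits on the aromatic nitrogen. Among the compounds with values here, no measured step therefore bears on it, and the size and direction of the coming step cannot be read from the data. Compound 4 is expected to give about 400 nM, within a range from 60 nM to 3000 nM. This estimate means an expected step of a 4.7-fold higher number from compound 3 to compound 4 (0.67 log units; beyond the scatter), a cautious allowance for an untested change.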

Compound 4, concentration lethal to 50% of the cells: 168 nM
For compound 4 the middle estimate is 2.4-fold (0.38 log units) above the measured one, and the stated range covers the measured number.
By their numbers in this assay, from the lowest: compounds 3 and 4 (each within the scatter of the next); then compound 2.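

The aromatic nitrogen is a place that neither earlier step touched, and the first change there does not separate the two compounds in this assay: a 2.0-fold higher number from compound 3 to compound 4 (0.30 log units; within the scatter). Compound 4 thus shows that isopropyl can give way to the larger 2-(methoxycarbonyl)ethyl, which unlike isopropyl has hydrogen-bond acceptors, while the number stays within the scatter, in contrast to a change on an aromatic carbon such as this one, with hydrogen in place of chloro: a 120-fold lower number from compound 2 to compound 3 (2.08 log units; beyond the scatter). No measurement shown here accounts for why this change on the nitrogen leaves the number within the scatter.

On these data alone, this is a single pair at the nitrogen, so it remains open whether other groups there, such as a carboxylic acid on the same chain, an amine or a longer chain, would also stay within the scatter of compound 3. As far as these compounds go, it also remains open whether 2-(methoxycarbonyl)ethyl would give a similar result on a core carrying chloro, or with trifluoromethyl in place of methoxy.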